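The compounds below may be only part of what the source reports. "The series", "measured", "known", "first", "only" and "open" are said of these compounds alone.

Compound 1 `O=C1O[C@@H](CO)CN1c1ccc(-n2cc(-c3ccccn3)cn2)c(F)c1`: 1.67 in a physicochemical assay for lipophilicity, read by HPLC, measured as octanol-water partition; on this read-out lower numbers stand for lower lipophilicity and higher numbers for higher lipophilicity
Compound 2 `O=C1CCC(=O)N1C[C@H]1CN(c2ccc(-n3cc(-c4ccccn4)cn3)c(F)c2)C(=O)O1`: 1.58
Compound 3 `O=C1O[C@@H](CSc2cccs2)CN1c1ccc(-n2cc(-c3ccccn3)cn2)c(F)c1`: 4.29

Compound 3 stands highest of the three in this assay, with compound 1 and compound 2 both far below it. Compound 4 `NC(=O)[C@H]1CN(c2ccc(-n3cc(-c4ccccn4)cn3)c(F)c2)C(=O)O1` differs from compound 3 by carbamoyl in place of ((thiophen-2-yl)sulfanyl)methyl on a saturated ring carbon. Among the compounds with values here, the steps that bear on this change are a number 2.62 log units higher from compound 1 to compound 3 (beyond the scatter) and a number 2.71 log units higher from compound 2 to compound 3 (beyond the scatter), both large rises on introducing the (thiophen-2-yl)sulfanyl group; the step to compound 4 removes that group again and puts in a carbamoyl with one hydrogen-bond donor and one acceptor. A large fall in this assay is therefore expected, a number 2.99 log units lower from compound 3 to compound 4 (beyond the scatter), bringing compound 4 to the neighbourhood of compound 1 and compound 2. Compound 4 is estimated at 1.3, with a range of 0.7 to 1.9.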

Compound 4, partition coefficient: 1.59
Beside the measured number, compound 4's estimate is 0.29 log units below it; measured number inside the range.
By their numbers in this assay, from the lowest: compounds 2, 4 and 1 (each within the scatter of the next); then compound 3.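

In this assay, carbamoyl in place of ((thiophen-2-yl)sulfanyl)methyl on this saturated ring carbon gives a number 2.70 log units lower from compound 3 to compound 4 (beyond the scatter), so the high reading of compound 3 does not survive this change. Carbamoyl, attached directly to the ring, reads level with the two groups that carry a saturated chain carbon, with a number 0.01 log units higher from compound 2 to compound 4 (within the scatter) and a number 0.08 log units lower from compound 1 to compound 4 (within the scatter), so these three groups are not separated in this assay. No evidence is available on why they read alike.

From the compounds shown here alone, whether an amine or a carboxylic acid here would read with compound 1, compound 2 and compound 4 remains open. Also open, going by these compounds, is whether a methylsulfanylmethyl group would retain the high reading of compound 3.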